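The source may hold more compounds than are shown below. What is called first, only, known or untested is meant among the compounds shown, and "the series" means these compounds.

Of the compounds shown here, two that share a core have been measured in an ADME assay on microsomes from liver (Rattus norvegicus), read by LC-MS, using NADPH, with a stated time of 10 min, tested at 0.5 uM; a lower number here means that less of the compound is left, a higher number that more of the compound is left. Compound 1 (`Cc1nc2cc(-c3ccc(OCc4ccccc4)cc3)nn2c(-c2cc(F)c3c(c2C)CCCO3)c1C(OC(C)(C)C)C(=O)O`) gives 79%. Compound 2 (`Cc1nc2cc(-c3cccc(-c4ccccc4)c3)nn2c(-c2cc(F)c3c(c2C)CCCO3)c1[C@H](OC(C)(C)C)C(=O)O`) gives 96%, the higher of the two numbers, and the gap between them lies beyond the usual scatter of repeats. These two compounds differ in more than one place, so no single structural change has a measured effect here.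

Compound 3 (`COc1ccc(-c2cccc(-c3cc4nc(C)c([C@H](OC(C)(C)C)C(=O)O)c(-c5cc(F)c6c(c5C)CCCO6)n4n3)c2)cn1`) departs from compound 2 in one place: 6-methoxypyridin-3-yl in place of phenyl on an aromatic carbon. This puts 6-methoxypyridin-3-yl in place of phenyl on an aromatic carbon. A small fall is the likelier direction, because compound 2 stands at 96% and has little room to rise. The estimated change, a number 8 percentage points lower from compound 2 to compound 3 (within the scatter), stays within the scatter. For compound 3 the expected value is 88%, with an estimated range of 70% to 99%.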

Compound 3, percent of the compound remaining: 100%
Estimate against measurement, compound 3: 12 percentage points below; measured number outside the range, above it.
By their numbers in this assay, from the lowest: compound 1; then compounds 2 and 3 (each within the scatter of the next).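

In this assay, putting 6-methoxypyridin-3-yl in place of phenyl gives a number 4 percentage points higher from compound 2 to compound 3 (within the scatter) and so does not separate the two compounds. This place, on an aromatic carbon meta to a large group, therefore takes a larger group, one with a hetero atom in its ring and with hydrogen-bond acceptors, with no step beyond the usual scatter. No measurement shown here offers an explanation for this result.

The compounds shown leave open whether the ring nitrogen or the methoxy group matters more, a question that a plain pyridin-3-yl ring and a methoxyphenyl ring could help to separate. Also open, on these data alone, is how a quite different group at the same place, such as an amine or a carboxylic acid, would fare in this assay.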